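Quinolinecarboxylic acid amides: a switch from methyl to fluorine

The compounds below may be only part of what the source reports. "The series", "measured", "known", "first", "only" and "open" are said of these compounds alone.

Measured compounds:
Compound 1, `COc1cc(-c2cc(C(=O)O)c3ccccc3n2)ccc1OCC(=O)Nc1cccc(C)c1`, 1.5
Compound 2, `COc1cc(-c2cc(C(=O)O)c3ccccc3n2)ccc1OCC(=O)Nc1ccc(C)cc1`, 1.2

In a physicochemical assay for lipophilicity, using the shake flask method, in phosphate buffer, measured as octanol-water partition, at pH 7.4 (a higher number here means a more lipophilic compound, a lower number a more polar compound), compound 2 gives the lowest of the two numbers, and its nearest neighbour is compound 1, from which it differs only in the arrangement of the methyl on the amide-bound phenyl; the change a number 0.30 log units lower from compound 1 to compound 2 (within the scatter) lies within the scatter. Compound 3, `COc1cc(-c2cc(C(=O)O)c3ccccc3n2)ccc1OCC(=O)Nc1ccccc1F`, has not yet been measured in this assay. It differs from compound 2 by 2-fluorophenyl in place of 4-methylphenyl on an amide-type nitrogen. For the measured compounds named here, no measured step covers a swap of methyl for fluorine, so the one step that exists, from compound 1 to compound 2, speaks only to how little a rearrangement on that phenyl moves the number. Compound 3 is therefore expected to sit close to compound 2, with at most a modest step, a number 0.20 log units lower from compound 2 to compound 3 (within the scatter), towards the less lipophilic side. The estimate for compound 3 is 1, in the range 0.5 to 1.5.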

Compound 3, distribution coefficient: 0.9
Estimate against measurement, compound 3: 0.10 log units above; low and high end bracket the measured number.
By their numbers in this assay, from the lowest: compounds 3, 2 and 1 (each within the scatter of the next, the first and the last beyond it).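

In this assay, for the compounds shown here, the amide-bound phenyl carries fluorine instead of methyl for the first time, and replacing 3-methylphenyl with 2-fluorophenyl gives a number 0.60 log units lower from compound 1 to compound 3 (beyond the scatter) on the amide-type nitrogen, whereas replacing 4-methylphenyl with 2-fluorophenyl gives a number 0.30 log units lower from compound 2 to compound 3 (within the scatter) and so stays inside it. Substitution on this phenyl can therefore move the number past the scatter, which the shift of the methyl alone did not do, but only one of the two swaps to 2-fluorophenyl does so. No supporting measurement is available to explain this result.

The compounds shown never place methyl and fluorine at the same point on the phenyl, so the identity of the substituent and its placement cannot be separated. From the compounds shown here alone, how a chlorine or an amine on that phenyl would read also remains open.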